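The compounds below may be only part of what the source reports. "The series", "measured", "known", "first", "only" and "open" are said of these compounds alone.

Measured compounds:
Compound 1 `Cc1c(CNC[C@@H]2CCCN3CCCC[C@H]23)cc(-c2ccccc2)n1Nc1ccnc2cc(Cl)ccc12`: 13500 nM
Compound 2 `Cc1c(CN2CCCC2)cc(-c2ccccc2)n1Nc1ccnc2cc(Cl)ccc12`: 12900 nM

For the measured compounds named here, only two numbers are known in an ADME assay on HMEC-1 cells (Homo sapiens) for cytotoxicity, read by MTT assay (on this read-out higher numbers stand for weaker inhibition and lower numbers for stronger inhibition), and compound 1 holds one of them; the other, from compound 2, sits practically on top of it, as the step of a 1.0-fold lower number from compound 1 to compound 2 (0.02 log units; within the scatter) shows. That single step replaced a large two-ring group on a saturated chain carbon bound to an aromatic carbon with a small one-ring group, and the read-out did not move.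

Compound 3 `Cc1c(CNCC[C@@H]2CCCN3CCCC[C@H]23)cc(-c2ccccc2)n1Nc1ccnc2cc(Cl)ccc12` keeps the two-ring group of compound 1 and alters it only slightly: a group of 11 heavy atoms (10 carbon, 1 nitrogen; 2 six-membered non-aromatic rings with 1 hetero atom each) in place of a group of 10 heavy atoms (9 carbon, 1 nitrogen; 2 six-membered non-aromatic rings with 1 hetero atom each), on a saturated chain carbon bound to an amine nitrogen. Going by the values given here, the one step on record, in which a far larger replacement left the number unchanged, bears on this move and suggests nothing beyond the scatter is expected here either, giving an estimated step of a 1.0-fold lower number from compound 1 to compound 3 (0.02 log units; within the scatter). For compound 3 the expected value in this assay is therefore 13000 nM, with a range of 6500 nM to 27000 nM.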

Compound 3, half-maximal inhibitory concentration: 14600 nM
Estimate against measurement, compound 3: 1.1-fold (0.05 log units) below; the range from low to high includes it.
By their numbers in this assay, from the lowest: compounds 2, 1 and 3 (each within the scatter of the next).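

In this assay the group of 11 heavy atoms in place of the group of 10 heavy atoms, on a saturated chain carbon bound to an amine nitrogen, gives a 1.1-fold higher number from compound 1 to compound 3 (0.03 log units; within the scatter). The earlier step swapped the whole two-ring group for a small one-ring group, whereas this one keeps both six-membered rings and shows that this smaller change at a new place also cannot be told apart from repeat-measurement scatter. No supporting data bear on why the number holds steady here.

The compounds shown leave open whether a carboxylic acid at this place, or a chain longer than the one in compound 3, would give a number beyond the scatter. They also leave open whether an amide or a hydroxyl group on the shared core would move the number in this assay at all.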